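Regioisomer step from compound 3 to compound 4

The source may report more compounds than this note shows. Statements on the series, on what has been measured and on what is new or still open speak of the compounds shown alone.

In a functional assay (Homo sapiens) for inhibition (on this read-out lower numbers stand for stronger inhibition and higher numbers for weaker inhibition), compound 3 `CSc1cc(CSc2nc(-c3ccc(F)cc3)c(-c3ccncc3)[nH]2)ccc1O` gives 280 nM and compound 2 `Oc1cccc(CSc2nc(-c3ccc(F)cc3)c(-c3ccncc3)[nH]2)c1` gives 310 nM, with a 1.1-fold lower number from compound 2 to compound 3 (0.04 log units; within the scatter) staying within the scatter. Compound 1 `CSc1ccccc1CSc1nc(-c2ccc(F)cc2)c(-c2ccncc2)[nH]1` gives 6700 nM, and both a 22-fold lower number from compound 1 to compound 2 (1.33 log units; beyond the scatter) and a 24-fold lower number from compound 1 to compound 3 (1.38 log units; beyond the scatter) are large steps.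

Compound 4 `CSc1ccc(O)c(CSc2nc(-c3ccc(F)cc3)c(-c3ccncc3)[nH]2)c1` has the same atoms, joined differently: 2-hydroxy-5-(methylsulfanyl)phenyl in place of 4-hydroxy-3-(methylsulfanyl)phenyl on a saturated chain carbon bound to a sulfur. For the measured compounds named here, no measured step isolates this exchange. Going by the values given here, the closest evidence is a 24-fold lower number from compound 1 to compound 3 (1.38 log units; beyond the scatter), since compound 1 is the only measured compound whose group, 2-(methylsulfanyl)phenyl, is named with a 2-substituent, as the entering group is. That substituent is methylsulfanyl rather than hydroxy, so only part of this step is expected to carry over. A moderate move to a higher number is therefore expected, estimated as a 3.2-fold higher number from compound 3 to compound 4 (0.51 log units; beyond the scatter). For compound 4 the estimated value is 900 nM, with an expected range of 200 nM to 4000 nM.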

Compound 4, half-maximal inhibitory concentration: 740 nM
For compound 4 the middle estimate is 1.2-fold (0.09 log units) above the measured one, and the stated range covers the measured number.
By their numbers in this assay, from the lowest: compounds 3 and 2 (each within the scatter of the next); then compound 4; then compound 1.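

Rearranging the same atoms on the phenyl group is enough to move the number in this assay, with a 2.6-fold higher number from compound 3 to compound 4 (0.42 log units; beyond the scatter) as the result, so this place responds to the arrangement of the hydroxy and methylsulfanyl groups as well as to their presence. The 2-hydroxy-5-(methylsulfanyl)phenyl group gives no gain over the simpler 3-hydroxyphenyl group, as a 2.4-fold higher number from compound 2 to compound 4 (0.38 log units; beyond the scatter) shows, yet it keeps a clear advantage over 2-(methylsulfanyl)phenyl, with a 9.1-fold lower number from compound 1 to compound 4 (0.96 log units; beyond the scatter) on that comparison. No measurement on hand explains why the arrangement matters.

The compounds shown leave open how much of this difference follows the hydroxy group and how much follows the methylsulfanyl group. Also open, on these data alone, is whether an amine or a carboxylic acid could stand in place of the hydroxy group on the phenyl ring.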